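The source may report more compounds than this note shows. Statements on the series, on what has been measured and on what is new or still open speak of the compounds shown alone.

Compound 2 `COc1ccc(/C=C\c2cc(OC)c(OC)c(OC)c2)cc1OCc1ccccc1` is measured in a functional assay on HT-29 cells (Homo sapiens) for inhibition, read by MTT assay, with a stated time of 3 days (on this read-out higher numbers stand for weaker inhibition and lower numbers for stronger inhibition), where compound 2 gives 39000 nM. That is the lowest of the three numbers shown, though compound 3 `COc1ccc(COc2cc(/C=C\c3cc(OC)c(OC)c(OC)c3)ccc2OC)cc1`, which gives 47000 nM, sits within the scatter, as a 1.2-fold higher number from compound 2 to compound 3 (0.08 log units; within the scatter) shows. Compound 1 `C/C=C/COc1cc(/C=C\c2cc(OC)c(OC)c(OC)c2)ccc1OC` gives 161000 nM, and the steps of a 4.1-fold lower number from compound 1 to compound 2 (0.62 log units; beyond the scatter) and a 3.4-fold lower number from compound 1 to compound 3 (0.53 log units; beyond the scatter) were both modest. Compound 4 `COc1ccc(/C=C\c2cc(OC)c(OC)c(OC)c2)cc1OCCC/C=C/c1ccc(Br)cc1` differs from compound 2 by a group of 11 heavy atoms (10 carbon, 1 bromine; one six-membered aromatic ring of carbon only) in place of a group of 6 heavy atoms (6 carbon; one six-membered aromatic ring of carbon only), on a saturated chain carbon bound to an oxygen on an aromatic ring. Within the data shown here, no measured step swaps one aromatic-ring group for a larger one of this kind, so the nearest guides are the modest steps from compound 1 and the flat step from compound 2 to compound 3. The step expected is therefore a 1.0-fold higher number from compound 2 to compound 4 (0.01 log units; within the scatter), close to none beyond the scatter. Compound 4 is estimated at 40000 nM, with a range from 15000 nM to 120000 nM.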

Compound 4, half-maximal inhibitory concentration: 11000 nM
Compound 4: the middle estimate sits 3.6-fold (0.56 log units) above what was measured; the whole stated range lies above it.
By their numbers in this assay, from the lowest: compound 4; then compounds 2 and 3 (each within the scatter of the next); then compound 1.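

On this saturated chain carbon bound to an oxygen on an aromatic ring, the bromine-bearing group goes beyond what the phenyl and 4-methoxyphenyl groups reached: there is a 3.5-fold lower number from compound 2 to compound 4 (0.55 log units; beyond the scatter) and a 4.3-fold lower number from compound 3 to compound 4 (0.63 log units; beyond the scatter), although those two groups gave values within the scatter of each other. With a 15-fold lower number from compound 1 to compound 4 (1.17 log units; beyond the scatter), compound 4 gives the strongest inhibition of the four compounds. No measurement shown gives a cause for this gain. From the compounds shown here alone, whether the bromine or the longer chain with its double bond carries the gain stays open, as does the effect of an amine or a carboxylic acid in this place.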